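Replacing 2-fluorophenyl with 3-cyanophenyl at the assay limit

This account rests on a few compounds, and the source may have more. Where it says the series, first, only, none or still open, it means among the compounds named here.

Measured in an ADME assay on MCF-10A cells (Homo sapiens) for inhibition, with a stated time of 48 h; a higher number here means a weaker inhibitor, a lower number a stronger inhibitor:
Compound 1 `O=C(Nc1ccc(C(F)(F)F)cc1)N1CCC[C@H]1c1nc(-c2ccccc2)no1`: > 50000 nM (a limit)
Compound 2 `O=C(Nc1ccc(Cl)cc1)N1CCC[C@H]1c1nc(-c2ccccc2F)no1`: > 50000 nM (a limit)

In this assay compound 2 stands at > 50000 nM, and this is a limit of the assay rather than a number. The whole measured set sits in the same place: the limit of > 50000 nM in this assay, at which 2 of the 2 values shown sit.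

Compound 3 `N#Cc1cccc(-c2noc([C@@H]3CCCN3C(=O)Nc3ccc(Cl)cc3)n2)c1` keeps the rest of compound 2 but carries 3-cyanophenyl in place of 2-fluorophenyl, on an aromatic carbon of a five-membered aromatic ring with 2 nitrogen and 1 oxygen: 3-cyanophenyl in place of 2-fluorophenyl on an aromatic carbon.

Among the compounds with values here, no measured pair in this set shows what a single change does, so any forecast here is cautious. Compound 3 is expected to stay where the others are, on the evidence that compound 2 gives > 50000 nM. The expected change is a number no higher from compound 2 to compound 3 (the limit leaves the size open), which would be nothing beyond the scatter. A report of only a limit is the likeliest outcome for compound 3. For compound 3 the estimate is 50000 nM, with an expected range from 20000 nM to 100000 nM.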

Compound 3, half-maximal inhibitory concentration: > 50000 nM
Compound 3 gave a limit, no number; the forecaster's own chance of this, stated with the estimate: 80%; the middle value sits exactly at the limit.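

In this assay compound 3 gives > 50000 nM, which is a limit of the assay and not a number. Compound 2 also stands at a limit, so no step can be read between compound 2 and compound 3. The compounds shown leave open what 3-cyanophenyl in place of 2-fluorophenyl does, and how strongly any of them inhibits, as the whole set offers only this: the limit of > 50000 nM in this assay, at which 3 of the 3 values shown sit.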